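This account rests on a few compounds, and the source may have more. Where it says the series, first, only, none or still open, it means among the compounds named here.

Values in a functional assay on HepG2 cells (Homo sapiens) for inhibition, read by MTT assay, with a stated time of 48 h; on this read-out higher numbers stand for weaker inhibition and lower numbers for stronger inhibition:
compound 1 `COc1ccc(-c2nc3ccccn3c2Sc2ccccc2)cc1` gives 54200 nM
compound 2 `C(=C/c1nc2ccccn2c1Sc1ccccc1)\c1ccccc1` gives 8800 nM
compound 3 `CSc1ccc(-c2nc3ccccn3c2Sc2ccccc2)cc1` gives 7600 nM

Compound 3 and compound 2 lie within the scatter of each other (a 1.2-fold lower number from compound 2 to compound 3 (0.06 log units; within the scatter)), and compound 1 stands clearly apart (a 7.1-fold lower number from compound 1 to compound 3 (0.85 log units; beyond the scatter)).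

Compound 4 `c1ccc(Sc2c(-c3cccs3)nc3ccccn23)cc1` has thiophen-2-yl in place of 4-(methylsulfanyl)phenyl on an aromatic carbon. All three measured steps fall at this same carbon or on the group it carries. The two beyond the scatter are modest, a 6.2-fold lower number from compound 1 to compound 2 (0.79 log units; beyond the scatter) and a 7.1-fold lower number from compound 1 to compound 3 (0.85 log units; beyond the scatter), while a 1.2-fold lower number from compound 2 to compound 3 (0.06 log units; within the scatter) replaces the whole group and stays within the scatter. Among the measured compounds shown here, no measured compound carries thiophen-2-yl, so the direction is uncertain. A modest move towards a higher number in this assay is expected, since compound 3 holds the low end of the range. The expected step is a 2.1-fold higher number from compound 3 to compound 4 (0.32 log units; beyond the scatter). Compound 4 is estimated at 16000 nM, with an expected range of 6000 nM to 45000 nM.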

Compound 4, half-maximal inhibitory concentration: 17100 nM
Beside the measured number, compound 4's estimate is 1.1-fold (0.03 log units) below it; low and high end bracket the measured number.
By their numbers in this assay, from the lowest: compounds 3, 2 and 4 (each within the scatter of the next, the first and the last beyond it); then compound 1.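

In this assay, thiophen-2-yl shows that a five-membered aromatic ring with 1 hetero atom is accepted on this carbon: compound 4 stays clear of the 4-methoxyphenyl compound (a 3.2-fold lower number from compound 1 to compound 4 (0.50 log units; beyond the scatter)) and cannot be told apart from the 2-phenylethenyl compound (a 1.9-fold higher number from compound 2 to compound 4 (0.29 log units; within the scatter)). The change from 4-(methylsulfanyl)phenyl, with 8 heavy atoms, to thiophen-2-yl, with 5, costs only a modest amount (a 2.3-fold higher number from compound 3 to compound 4 (0.35 log units; beyond the scatter)), so a six-membered aromatic ring of carbon only is not needed for a number below that of compound 1. No measured property is available to account for these steps.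

Still open, from the compounds shown here alone, is how an amine or a carboxylic acid on the ring at this carbon would shift the number. Also open is what the phenylsulfanyl group contributes, since all the compounds shown carry it unchanged.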